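A few compounds are considered here, and "the series" means these few. Any claim that something is new, unique, unknown or untested is made for them only; others in the source may bear on it.

Compound 1 `O=C(O)c1cccc(-c2cnc(C(=O)CCc3ccc(-c4ccc(CN5CCCCC5)cc4)cc3)o2)n1`: 44 nM
Compound 2 `COC(=O)c1cccc(-c2cnc(C(=O)CCc3ccc(-c4ccc(CN5CCCCC5)cc4)cc3)o2)n1`: 9 nM
Compound 3 `O=C(O)c1ccc(-c2cnc(C(=O)CCc3ccc(COc4ccccc4)cc3)o2)nc1`: 4.6 nM

All three compounds were tested in an assay for inhibition of Fatty-acid amide hydrolase 1 (Rattus norvegicus); a lower number here means a stronger inhibitor, a higher number a weaker inhibitor. In this assay compound 1 gives 44 nM, the highest of the three numbers, so compound 1 is the weakest inhibitor among them. Compound 2 gives 9 nM and compound 3 gives 4.6 nM. For the measured compounds named here, the only step between two compounds that differ in a single place is a 4.9-fold lower number from compound 1 to compound 2 (0.69 log units; beyond the scatter), a modest gain that comes from changing the acid end of the molecule.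

Compound 4 `O=C(O)c1cccc(-c2cnc(C(=O)CCc3ccc(-c4ccc(CN5CCCC5)cc4)cc3)o2)n1` is built from compound 1 by a change at the other end: pyrrolidin-1-yl in place of piperidin-1-yl on a saturated chain carbon bound to an aromatic carbon. The ring that enters is one atom smaller than the one that leaves, keeps the single nitrogen, and sits in the same place on the saturated chain carbon bound to an aromatic carbon. Going by the values given here, none of the measured compounds shows this particular exchange, and the one measured step concerns a different part of the molecule, so it gives no guide to the size or direction of the effect. Shrinking the ring by one atom while keeping everything else is the kind of change that often stays within the usual scatter, so no step beyond the scatter is expected: the estimate for compound 4 is 40 nM, within 15 nM to 110 nM, corresponding to an expected step of a 1.1-fold lower number from compound 1 to compound 4 (0.04 log units; within the scatter).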

Compound 4, inhibition constant: 130 nM
Beside the measured number, compound 4's estimate is 3.3-fold (0.51 log units) below it; the measured number lies above the stated range.
By their numbers in this assay, from the lowest: compounds 3 and 2 (each within the scatter of the next); then compound 1; then compound 4.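

In this assay, replacing the piperidin-1-yl with pyrrolidin-1-yl on a saturated chain carbon bound to an aromatic carbon gives a 3.0-fold higher number from compound 1 to compound 4 (0.47 log units; beyond the scatter). This shows that the ring at this position is not a passive passenger: going from the six-membered ring to the five-membered ring, with the single nitrogen kept and the rest of the molecule unchanged, is enough to give a weaker inhibitor, and here the six-membered ring is the better of the two. For the compounds shown here, until now the only single-place step concerned the acid end of the molecule, so this is the first sign that the number also responds to a change at the far end, although nothing available explains why the smaller ring does worse.

As far as these compounds go, two rings give only a direction between them, so it remains open whether azepan-1-yl, with its seven-membered ring, would continue the trend or reverse it, and whether morpholin-4-yl or an open dimethylamino group would be tolerated at the same place. From the compounds shown here alone, it is also open whether the same exchange would cost as much on the methyl ester, compound 2.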